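Removing the Chloro Atom in a Benzyloxybenzylamine Series

The compounds below may be only part of what the source reports. "The series", "measured", "known", "first", "only" and "open" are said of these compounds alone.

Compound 1 `NC(=O)[C@H](CO)NCc1ccc(OCc2ccc(Cl)cc2)cc1` gives 1100 nM in an assay on mitochondria for inhibition of Amine oxidase [flavin-containing] B (Rattus norvegicus); a lower number here means a stronger inhibitor, a higher number a weaker inhibitor. Compound 2 `NC(=O)[C@H](CO)NCc1ccc(OCc2ccccc2)cc1` differs from it in one place, (hydrogen in place of chloro on an aromatic carbon), and in this assay compound 2 gives 410 nM, a step of a 2.7-fold lower number from compound 1 to compound 2 (0.43 log units; beyond the scatter). Compound 3 `C[C@H](NCc1ccc(OCc2ccc(Cl)cc2)cc1)C(N)=O` gives 2200 nM in this assay; its core differs from the core of compound 1 as follows, (hydrogen in place of hydroxy on a saturated chain carbon, two bonds along the chain from an amine nitrogen and a carbonyl carbon), a step of a 2.0-fold higher number from compound 1 to compound 3 (0.30 log units; within the scatter). Compound 4 `C[C@H](NCc1ccc(OCc2ccccc2)cc1)C(N)=O` has not yet been measured; it differs from compound 3 in the following way, (hydrogen in place of chloro on an aromatic carbon), the same change that separates compound 1 from compound 2. A step of similar size is expected here because the same change gave a 2.7-fold lower number from compound 1 to compound 2 (0.43 log units; beyond the scatter), so the expected step is a 2.6-fold lower number from compound 3 to compound 4 (0.41 log units; beyond the scatter). Compound 4 is thus estimated at 850 nM in this assay, most likely between 400 nM and 1800 nM.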

Compound 4, half-maximal inhibitory concentration: 260 nM
Compound 4: the middle estimate sits 3.3-fold (0.51 log units) above what was measured; measured number below the stated range.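

For the compounds shown here, removing the chloro group carried over in direction but not in size in this assay, with an 8.5-fold lower number from compound 3 to compound 4 (0.93 log units; beyond the scatter), so the step seen on the first core underrates the step on the second: the same change on two cores in this assay, a 2.7-fold lower number (0.43 log units; beyond the scatter) from compound 1 to compound 2 and an 8.5-fold lower number (0.93 log units; beyond the scatter) from compound 3 to compound 4, 3.2-fold (0.50 log units) apart, beyond the scatter of two such steps. The exchange of hydroxy for hydrogen does not carry over as one fixed step either, reading a 1.6-fold lower number from compound 2 to compound 4 (0.20 log units; within the scatter) on the core without chloro; each step lies within the scatter, but the gap between them does not: the same change on two cores in this assay, a 2.0-fold higher number (0.30 log units; within the scatter) from compound 1 to compound 3 and a 1.6-fold lower number (0.20 log units; within the scatter) from compound 2 to compound 4, 3.2-fold (0.50 log units) apart, beyond the scatter of two such steps. These two pairs show that the size of a step depends on the core carrying it, but they do not show why, and they give no rule for other cores.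

From the compounds shown here alone, whether the same holds for fluoro or methoxy in place of chloro remains open. So does the outcome with a carboxylic acid in place of the amide.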